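Difluoroindole variant in the diphenylmethylpiperazine series

The compounds below may be only part of what the source reports. "The series", "measured", "known", "first", "only" and "open" are said of these compounds alone.

For the measured compounds named here, compound 3 `Fc1cccc2c1ccn2CCCCN1CCN(C(c2ccccc2)c2ccccc2)CC1` gives 150 nM in an assay on RPMI-8226 cells for antagonist activity at P2X purinoceptor 7 (Homo sapiens), read by calcium flux (a higher number here means a weaker inhibitor, a lower number a stronger inhibitor), and stands lowest of the three numbers measured so far. Compound 1 `Cc1cc2ncn(CCCCN3CCN(C(c4ccccc4)c4ccccc4)CC3)c2cc1C` gives 770 nM in this assay, and compound 2 `Cc1cccc2ccn(CCCCN3CCN(C(c4ccccc4)c4ccccc4)CC3)c12` gives 2300 nM. The steps into compound 3 are a 5.1-fold lower number from compound 1 to compound 3 (0.71 log units; beyond the scatter) and a 15-fold lower number from compound 2 to compound 3 (1.19 log units; beyond the scatter); between the other two compounds the step is a 3.0-fold higher number from compound 1 to compound 2 (0.48 log units; beyond the scatter).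

Compound 4 `Fc1cc2ccn(CCCCN3CCN(C(c4ccccc4)c4ccccc4)CC3)c2cc1F` differs from compound 3 by a group of 11 heavy atoms (8 carbon, 1 nitrogen, 2 fluorine; one five-membered aromatic ring with 1 hetero atom, one six-membered aromatic ring of carbon only) in place of a group of 10 heavy atoms (8 carbon, 1 nitrogen, 1 fluorine; one five-membered aromatic ring with 1 hetero atom, one six-membered aromatic ring of carbon only), on a saturated chain carbon, four bonds along the chain from an amine nitrogen in a ring. Going by the values given here, none of the measured steps turns one fluoroindole into another; each swaps the whole bicycle, so they bear on the present change only loosely. The steps from compound 1 and compound 2 into compound 3 show the fluoroindole to be the strongest of the three bicycles tried, and compound 4 keeps that bicycle with a second fluorine. Among the compounds with values here, no measured step tells how a second fluorine acts here. The step of a 1.5-fold higher number from compound 3 to compound 4 (0.17 log units; within the scatter) is expected to stay within the scatter, in either direction. In this assay compound 4 is estimated at 220 nM, with a range from 70 nM to 700 nM.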

Compound 4, half-maximal inhibitory concentration: 130 nM
Estimate against measurement, compound 4: 1.7-fold (0.23 log units) above; the range from low to high includes it.
By their numbers in this assay, from the lowest: compounds 4 and 3 (each within the scatter of the next); then compound 1; then compound 2.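

In this assay, the group with two fluorines in place of 4-fluoro-1H-indol-1-yl leaves the number within the scatter, with a 1.2-fold lower number from compound 3 to compound 4 (0.06 log units; within the scatter). The place on a saturated chain carbon, four bonds along the chain from an amine nitrogen in a ring, therefore holds this level with more than one fluoroindole group, and the distance to the other two compounds remains, with an 18-fold lower number from compound 2 to compound 4 (1.25 log units; beyond the scatter) and a 5.9-fold lower number from compound 1 to compound 4 (0.77 log units; beyond the scatter). No supporting data bear on why this swap leaves the number within the scatter.

As far as these compounds go, how much each fluorine of the entering group contributes stays open. So does whether chloro, nitrile or trifluoromethyl on the same bicycle, or a longer chain to the piperazine amine nitrogen, would hold this level.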